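The source may hold more compounds than are shown below. What is called first, only, known or untested is meant among the compounds shown, and "the series" means these compounds.

In a functional assay on SK-MEL-28 cells (Homo sapiens) for inhibition, read by MTT assay, with a stated time of 48 h (a higher number here means a weaker inhibitor, a lower number a stronger inhibitor), compound 1 `CCc1ccc(-c2nc3ccccn3c2Sc2ccccc2)cc1` reads > 100000 nM, which is a limit of the assay and not a number. Within the data shown here, compound 2 `Cc1ccc2nc(-c3ccc(Cl)cc3)c(Sc3ccccc3)n2c1` gives 81500 nM, the only actual number so far. Compound 3 `Clc1ccc(-c2nc3ccccn3c2Sc2ccccc2)cc1` departs from compound 2 at one place: hydrogen in place of methyl on an aromatic carbon. Among the measured compounds shown here, no measured step covers this change, so no shift beyond the usual scatter is expected in this assay, and the expected 1.2-fold higher number from compound 2 to compound 3 (0.07 log units; within the scatter) is small. For compound 3 the estimated value is 95000 nM, with an expected range of 45000 nM to 180000 nM.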

Compound 3, half-maximal inhibitory concentration: 73100 nM
Compound 3: middle estimate off by 1.3-fold (0.11 log units), on the high side; the range from low to high includes it.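

In this assay, hydrogen in place of methyl on this aromatic carbon gives a 1.1-fold lower number from compound 2 to compound 3 (0.05 log units; within the scatter), so this first single-place comparison at the position shows no shift beyond the scatter. Chloro in place of ethyl on the other aromatic ring gives an at least 1.3-fold lower number from compound 1 to compound 3 (0.13 log units; that floor lies within the scatter). Compound 1 stands at a limit of the assay and not at a number, so that step gives only a floor: the limit of > 100000 nM in this assay, at which 1 of the 3 values shown sits.

Still open, from the compounds shown here alone, is whether an amine or a carboxylic acid on the methyl-bearing aromatic carbon would move the number beyond the scatter. Also open, going by these compounds, is how a longer chain in place of chloro would read.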